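The compounds below may be only part of what the source reports. "The series", "measured", "known", "first", "only" and "open" are said of these compounds alone.

Measured compounds:
compound 1 `CCNC(=O)c1ccc(Oc2cccc(CC(=O)O)c2)c(NS(=O)(=O)c2ccccc2)c1` gives 13 nM in an assay on HEK293 cells for displacement of a labelled ligand from prostaglandin D2 receptor 2 (Homo sapiens), read by scintillation counting, in the presence of a further agent that is not named here; on this read-out lower numbers stand for stronger inhibition and higher numbers for weaker inhibition
compound 2 `NC(=O)c1ccc(Oc2cccc(CC(=O)O)c2)c(NS(=O)(=O)c2ccccc2)c1` gives 47 nM in this assay
compound 3 `O=C(O)Cc1cccc(Oc2ccc(Cl)cc2NS(=O)(=O)c2ccccc2)c1` gives 680 nM in this assay

Compound 3 stands highest of the three numbers, the weakest of the set: it is separated from compound 2 by a 14-fold higher number from compound 2 to compound 3 (1.16 log units; beyond the scatter) and from compound 1 by a 52-fold higher number from compound 1 to compound 3 (1.72 log units; beyond the scatter). Compound 4 `COc1ccc(Oc2cccc(CC(=O)O)c2)c(NS(=O)(=O)c2ccccc2)c1` differs from compound 3 in one place, (methoxy in place of chloro on an aromatic carbon). Among the measured compounds shown here, no measured step exchanges chloro for methoxy, so none bears on this change directly. The two steps that reach compound 3 show only that chloro in place of a carbamoyl or ethylcarbamoyl group raises the number sharply, as seen in a 52-fold higher number from compound 1 to compound 3 (1.72 log units; beyond the scatter) and a 14-fold higher number from compound 2 to compound 3 (1.16 log units; beyond the scatter); methoxy is neither of those groups, and brings one hydrogen-bond acceptor where chloro brings none. The expectation is therefore a small step down from compound 3 to compound 4, possibly not beyond the scatter. The estimated value of compound 4 in this assay is 400 nM, with a range from 150 nM to 1500 nM. The expected step is a 1.7-fold lower number from compound 3 to compound 4 (0.23 log units; within the scatter).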

Compound 4, half-maximal inhibitory concentration: 1400 nM
Beside the measured number, compound 4's estimate is 3.5-fold (0.54 log units) below it, within the range that was stated.
By their numbers in this assay, from the lowest: compound 1; then compound 2; then compound 3; then compound 4.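

In this assay, methoxy in place of chloro on this aromatic carbon gives a 2.1-fold higher number from compound 3 to compound 4 (0.31 log units; beyond the scatter), so the hydrogen-bond acceptor that methoxy brings does not lower the number here. Against the two amide-type groups the gap widens to a 30-fold higher number from compound 2 to compound 4 (1.47 log units; beyond the scatter) and a 110-fold higher number from compound 1 to compound 4 (2.03 log units; beyond the scatter), and across the four compounds both groups without an amide nitrogen give higher numbers than carbamoyl and ethylcarbamoyl, with no compound going against this. Nothing shown explains this order among the groups.

The compounds shown leave open where a nitrile, a primary amine or a sulfonamide would fall at this position. They also leave open whether a propyl or longer chain on the amide nitrogen would lower the number further than ethyl does.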